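The compounds below may be only part of what the source reports. "The series", "measured", "known", "first", "only" and "open" are said of these compounds alone.

Measured compounds:
Compound 1, `CN(C)c1ccc(Nc2c(NCCCCCC(=O)NO)c(=O)c2=O)cc1`. In an ADME assay on cells (Hepatocyte, Homo sapiens) for pharmacokinetics, read by LC-MS, with a stated time of 90 min, tested at 1 uM (a lower number here means slower removal, a higher number faster removal of the compound), compound 1 gives < 5 uL/min, which is a limit of the assay and not a number.
Compound 2, `O=C(CCCCCNc1c(Nc2ccc(C(F)(F)F)cc2)c(=O)c1=O)NO`. In this assay compound 2 gives 11 uL/min.

Compound 1 therefore stands at the limit of < 5 uL/min in this assay, at which 1 of the 2 values shown sits, so only a range is known for it in this assay, and it sits at the slow end of the two values shown. Going by the values given here, the one measured step, an at least 2.2-fold higher number from compound 1 to compound 2 (0.34 log units; beyond the scatter), concerns a substituent on the aromatic ring and leaves the chain untouched.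

Compound 3, `C[C@@H](CCCCC(=O)NO)Nc1c(Nc2ccc(N(C)C)cc2)c(=O)c1=O`, differs from compound 1 by methyl in place of hydrogen on a saturated chain carbon bound to a nitrogen on an aromatic ring and a saturated chain carbon. Among the compounds with values here, no measured step touches this chain carbon, so the step from compound 1 to compound 2 does not bear on it, and the data give no direct guide to its size or direction. A change within the scatter is the expectation, with the number for compound 3 likely to remain near the limit at which compound 1 sits or a little above it.

Compound 3 is therefore expected to give about 5 uL/min, within a range of 2 uL/min to 12 uL/min. This estimate means a step of a number no lower from compound 1 to compound 3 (the limit leaves the size open).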

Compound 3, intrinsic clearance in a liver preparation (reported as CLH), per the amount of preparation that the assay uses in the Hepatocyte assay: 3.6 uL/min
For compound 3 the middle estimate is 1.4-fold (0.14 log units) above the measured one, within the range that was stated.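

In the Hepatocyte assay no step can be read from compound 1 to compound 3, as compound 1 stands at a limit of the assay and not at a number. In a physicochemical assay for solubility, with a stated time of 24 h, tested at 30 mg/mL (a lower number here means a less soluble compound, a higher number a more soluble compound), compound 1 gives 1400000 nM and compound 3 gives 28000000 nM, a 20-fold higher number from compound 1 to compound 3 (1.30 log units; beyond the scatter). The compounds shown leave open how far methyl in place of hydrogen on this chain carbon moves the number in the Hepatocyte assay.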